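This account rests on a few compounds, and the source may have more. Where it says the series, first, only, none or still open, it means among the compounds named here.

Measured in a functional assay on PC-3 cells (Homo sapiens) for cytotoxicity, read by MTT assay, with a stated time of 72 h; a lower number here means that less compound is tolerated, a higher number that more compound is tolerated:
Compound 1 `CS/C(=N\C(=O)c1ccno1)NC(=O)c1ccno1` is recorded as a limit only, > 100000 nM.
Compound 2 `CS/C(=N\C(=O)c1ccco1)NC(=O)c1ccco1` is likewise recorded as a limit only, > 100000 nM.
Compound 3 `C[Se]/C(=N\C(=O)c1cccs1)NC(=O)c1cccs1` is also recorded as a limit only, > 100000 nM.

Among the measured compounds shown here, compound 3 stands together with the other two at the limit of > 100000 nM in this assay, at which 3 of the 3 values shown sit; no number separates it from compound 1 or compound 2, and no measured step can be drawn between any pair of them. Compound 4 `O=C(/N=C(/NC(=O)c1cccs1)[Se]Cc1ccccc1)c1cccs1` differs from compound 3 by phenyl in place of hydrogen on a saturated chain carbon bound to a selenium atom. Since compound 3 sits at the limit of > 100000 nM in this assay, at which 3 of the 3 values shown sit, the step in this assay is expected to be none beyond the scatter, with a limit again the most likely result. Compound 4 is expected to give 100000 nM, between 30000 nM and 300000 nM. The expected step is then a number no higher from compound 3 to compound 4 (the limit leaves the size open).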

Compound 4, concentration lethal to 50% of the cells: > 100000 nM
Compound 4: no number, only a limit; the forecaster's own chance of this, stated with the estimate: 75%; the middle value lies on the limit itself.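

In this assay compound 4 gives > 100000 nM, a limit and not a number, and compound 3 is also recorded only as a limit, so no step can be read between compound 3 and compound 4. Any order among the compounds shown stays open, as does the effect of any structural change, since all of them rest on one value: the limit of > 100000 nM in this assay, at which 4 of the 4 values shown sit.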